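Propyl for cyclopentyl on a shared pyrimidine-free core

The source may hold more compounds than are shown below. What is called first, only, known or untested is meant among the compounds shown, and "the series" means these compounds.

Compound 1 `CN1CCC(NC(=O)c2ccc(Nc3ncc([N+](=O)[O-])c(NC4CCCC4)n3)cc2)CC1` and compound 2 `CN1CCN(c2ccc(Nc3ncc(F)c(NC4CCCC4)n3)cc2)CC1` were both tested in a functional assay on HepG2 cells (Homo sapiens) for cytotoxicity, read by MTT assay, with a stated time of 48 h; on this read-out lower numbers stand for stronger inhibition and higher numbers for weaker inhibition. In this assay compound 1 gives 5800 nM, while compound 2 gives 25000 nM, the higher of the two numbers and a gap beyond the usual scatter, so compound 2 is the weaker of the pair. Compound 3 `CCCNc1nc(Nc2ccc(N3CCN(C)CC3)cc2)ncc1F` differs from compound 2 by propyl in place of cyclopentyl on a nitrogen on an aromatic ring. Among the measured compounds shown here, no measured pair shows this change, so only a small step is expected, likely none beyond the scatter, and the step from compound 2 to compound 3 is estimated at a 1.2-fold higher number from compound 2 to compound 3 (0.08 log units; within the scatter). Compound 3 is therefore expected to give about 30000 nM, within 10000 nM to 90000 nM.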

Compound 3, half-maximal inhibitory concentration: 35000 nM
The estimate for compound 3 lay 1.2-fold (0.07 log units) below the measured number; measured number inside the range.
By their numbers in this assay, from the lowest: compound 1; then compounds 2 and 3 (each within the scatter of the next).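

Replacing cyclopentylamino with propylamino removes the ring and shortens the group, yet in this assay the result is a 1.4-fold higher number from compound 2 to compound 3 (0.15 log units; within the scatter) and so no real change. On this nitrogen on an aromatic ring, the cyclopentyl ring is therefore not needed to keep the number where it stands. No measurement shown here offers an explanation for this.

Going by these compounds, whether a methyl, a longer chain such as hexyl, or a chain ending in an amine would also leave the number unchanged remains open. So does whether propyl would behave the same way on the core of compound 1.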